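Series notes: 1,3-thiazol-2-yl for oxetan-3-yl on the amide nitrogen

This account rests on a few compounds, and the source may have more. Where it says the series, first, only, none or still open, it means among the compounds named here.

Measured so far in an assay on HEK293 cells for agonist activity at transient receptor potential cation channel subfamily M member 8 (Homo sapiens), read by fluorescence and calcium flux, with a stated time of 15 min; a lower number here means that less compound is needed, a higher number that more compound is needed for the effect:
- compound 1, `Cc1ccc(OCC(=O)N(Cc2cccs2)C2COC2)cc1`: compound 1 gives 23000 nM
- compound 2, `CCN(Cc1cccn1C)C(=O)COc1ccc(C)cc1`: compound 2 gives 21300 nM
- compound 3, `CCN(Cc1cc[nH]c1)C(=O)COc1ccc(C)cc1`: compound 3 gives 21800 nM

All three numbers lie within the scatter of one another, so compound 1 cannot be told apart from compound 2 or compound 3 on the data shown. Within the data shown here, the only step between measured compounds that differ in one place is a 1.0-fold higher number from compound 2 to compound 3 (0.01 log units; within the scatter), a swap of one five-membered ring for another on a saturated chain carbon bound to an amide-type nitrogen, with no movement beyond the scatter.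

Compound 4, `Cc1ccc(OCC(=O)N(Cc2cccs2)c2nccs2)cc1`, differs from compound 1 as follows: 1,3-thiazol-2-yl in place of oxetan-3-yl on an amide-type nitrogen. Among the measured compounds shown here, no measured pair alters the group on the amide-type nitrogen itself, so the step from compound 2 to compound 3 bears on the new compound only loosely, as the one example of a ring swap, and that swap moved nothing. For the measured compounds named here, with no step reaching beyond the scatter, compound 4 is expected to give 20000 nM in this assay, with a range from 6000 nM to 60000 nM, meaning an expected step of a 1.2-fold lower number from compound 1 to compound 4 (0.06 log units; within the scatter) that does not exceed the scatter.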

Compound 4, half-maximal effective concentration: 2240 nM
Compound 4: the middle estimate sits 8.9-fold (0.95 log units) above what was measured, and the stated range ends above it.
By their numbers in this assay, from the lowest: compound 4; then compounds 2, 3 and 1 (each within the scatter of the next).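

In this assay, among these compounds, 1,3-thiazol-2-yl in place of oxetan-3-yl on an amide-type nitrogen gives a 10-fold lower number from compound 1 to compound 4 (1.01 log units; beyond the scatter) and is the first step beyond the scatter, so this position responds to a change of group where the one earlier ring swap, made on a saturated chain carbon, did not. The change exchanges a four-membered non-aromatic ring for a five-membered aromatic ring with 2 hetero atoms, and this single pair cannot separate ring size, aromaticity and the identity of the hetero atoms. Nothing in the data shown explains the step.

As far as these compounds go, it remains open whether the same position would respond in the same way to a phenyl or a pyridin-2-yl ring, which would help separate aromaticity from the nitrogen and sulfur of 1,3-thiazol-2-yl. From the compounds shown here alone, it is also open whether the step would persist with a different group on the saturated chain carbon of the amide-type nitrogen.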